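A few compounds are considered here, and "the series" means these few. Any claim that something is new, unique, unknown or untested is made for them only; others in the source may bear on it.

Compound 1 `COc1ccc(-c2sc(N)c(C(=O)c3ccc(Cl)cc3)c2C)cc1`: 1%
Compound 2 `CC(C)(C)Cc1c(-c2ccc(F)cc2)sc(N)c1C(=O)c1ccc(Cl)cc1`: 9%
Compound 3 `Cc1ccc(C(=O)c2c(N)sc(Br)c2CC(C)(C)C)cc1`: 1%

In an assay on CHO cells for displacement of a labelled ligand from adenosine receptor A3 (Homo sapiens), read by scintillation counting, tested at 10 uM (a lower number here means less inhibition, a higher number more inhibition at the concentration tested (going by the name of the read-out)), compound 2 stands highest of the three numbers, yet its gaps to compound 1 and to compound 3 both lie within the scatter, so the three cannot be placed in any order. Compound 4 `CC(C)(C)Cc1c(-c2cccs2)sc(N)c1C(=O)c1ccc(Cl)cc1` differs from compound 2 in one place: thiophen-2-yl in place of 4-fluorophenyl on an aromatic carbon. Within the data shown here, no measured pair shows this change, so its effect is not known from these data; all three measured compounds sit low, and no step beyond the scatter in either direction is expected. Compound 4 is therefore estimated to give 8% in this assay, with a range from 0% to 25%. The step this estimate means is a number 1 percentage points lower from compound 2 to compound 4 (within the scatter), which is expected to stay within the scatter.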

Compound 4, a percentage reported as inhibition, at one concentration (the size of the read-out at that concentration, not a potency): 1%
Compound 4: middle estimate off by 7 percentage points, on the high side; measured number inside the range.
By their numbers in this assay, from the lowest: compounds 1, 3, 4 and 2 (each within the scatter of the next).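

Thiophen-2-yl in place of 4-fluorophenyl, on the aromatic carbon next to the ring sulfur, is the only one-place comparison here in this assay and gives a number 8 percentage points lower from compound 2 to compound 4 (within the scatter) at this position. The two aromatic groups therefore cannot be told apart at this position, and both compounds remain low. Nothing available bears on the reason for this result. From the compounds shown here alone, what stays open is whether a group of another kind here, such as an amine or a carboxylic acid, would give a step beyond the scatter.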